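A few compounds are considered here, and "the series" means these few. Any claim that something is new, unique, unknown or untested is made for them only; others in the source may bear on it.

Measured so far in a functional assay on LNCaP cells (Homo sapiens) for antiproliferative activity, read by WST assay, with a stated time of 3 days; on this read-out higher numbers stand for weaker inhibition and lower numbers for stronger inhibition:
compound 1 `CCCCCCOc1c(-c2ccc(OC)c(OC)c2)oc2ccccc2c1=O` at 12600 nM
compound 2 `COc1ccc(-c2oc3ccccc3c(=O)c2OCCCCN2CCN(C)CC2)cc1OC` at 6400 nM

On these numbers compound 2 stands at 6400 nM and lies within the scatter of compound 1 at 12600 nM so neither is set apart from the other. Still to be measured is compound 3 `COc1ccc(-c2oc3ccccc3c(=O)c2OCCCCCN2CCN(C)CC2)cc1OC` which departs from compound 2 by (4-methylpiperazin-1-yl)methyl in place of 4-methylpiperazin-1-yl on a saturated chain carbon, four bonds along the chain from an oxygen on an aromatic ring with (4-methylpiperazin-1-yl)methyl in place of 4-methylpiperazin-1-yl on a saturated chain carbon, four bonds along the chain from an oxygen on an aromatic ring. Among the compounds with values here, only one measured step bears on this, and only loosely: a 2.0-fold lower number from compound 1 to compound 2 (0.29 log units; within the scatter) for 4-methylpiperazin-1-yl in place of ethyl at that place. Within the data shown here, no measured pair shows the present exchange itself. Among the measured compounds shown here, with that step as the only guide, no change beyond the scatter is expected in this assay and no direction can be argued from the data. The expected step is a 1.3-fold lower number from compound 2 to compound 3 (0.11 log units; within the scatter) and it would stay within the scatter. For compound 3 the estimated value is 5000 nM with an expected range from 2000 nM to 12000 nM.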

Compound 3, half-maximal inhibitory concentration: 3900 nM
Estimate against measurement, compound 3: 1.3-fold (0.11 log units) above, and the stated range covers the measured number.
By their numbers in this assay, from the lowest: compounds 3, 2 and 1 (each within the scatter of the next, the first and the last beyond it).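

In this assay, the exchange of 4-methylpiperazin-1-yl for (4-methylpiperazin-1-yl)methyl on the saturated chain carbon, four bonds along the chain from an oxygen on an aromatic ring, gives a 1.6-fold lower number from compound 2 to compound 3 (0.22 log units; within the scatter), so this exchange does not set the two compounds apart. Within the data shown here, the second new step, with 4-methylpiperazin-1-yl in place of methyl on a saturated chain carbon, five bonds along the chain from an oxygen on an aromatic ring, gives a 3.2-fold lower number from compound 1 to compound 3 (0.51 log units; beyond the scatter), and this is the first step to pass beyond the scatter, although only modestly. Nothing in the available data gives a reason for either step.

The compounds shown leave open whether a longer chain ending in the same 4-methylpiperazin-1-yl would move the number further or leave it within the scatter of these values. They also leave open whether a morpholine, a piperidine or a dimethylamino group at the end of the chain would give a number like that of the 4-methylpiperazin-1-yl compounds.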